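Cycloalkyl amide pair on the pyrrolidinyl core

The compounds below may be only part of what the source reports. "The series", "measured", "known", "first", "only" and "open" are said of these compounds alone.

Compound 1 `CC(C)=CCC/C(C)=C/CC/C(C)=C/CSC[C@H](NC(=O)CCCCCN1CCN(C)CC1)C(=O)NC1CCCCCC1` and compound 2 `CC(C)=CCC/C(C)=C/CC/C(C)=C/CSC[C@H](NC(=O)CCCCCN1CCN(C)CC1)C(=O)NC1CCCCCCC1` share a core; compound 3 `CC(C)=CCC/C(C)=C/CC/C(C)=C/CSC[C@H](NC(=O)CCCCCN1CCCC1)C(=O)NC1CCCCCC1` and compound 4 `CC(C)=CCC/C(C)=C/CC/C(C)=C/CSC[C@H](NC(=O)CCCCCN1CCCC1)C(=O)NC1CCCCCCC1` share another. The two cores differ by pyrrolidin-1-yl in place of 4-methylpiperazin-1-yl on a saturated chain carbon, five bonds along the chain from a carbonyl carbon. In a functional assay on MIA PaCa-2 cells (Homo sapiens) for cytotoxicity, read by fluorescence, with a stated time of 48 h (a lower number here means that less compound is needed, a higher number that more compound is needed for the effect), compound 1 gives 2700 nM and compound 2 gives 2500 nM; compound 3 gives 6800 nM. The core change alone is seen in a 2.5-fold higher number from compound 1 to compound 3 (0.40 log units; beyond the scatter).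

The change from compound 3 to compound 4 is cyclooctyl in place of cycloheptyl on an amide-type nitrogen, the same as cyclooctyl in place of cycloheptyl on an amide-type nitrogen; the place is the same in both. Where it was measured, a 1.1-fold lower number from compound 1 to compound 2 (0.03 log units; within the scatter), the step lies within the scatter.

For compound 4 in this assay a step of about a 1.1-fold lower number from compound 3 to compound 4 (0.04 log units; within the scatter) is expected, resting on compound 1 to compound 2 giving a 1.1-fold lower number from compound 1 to compound 2 (0.03 log units; within the scatter). Compound 4 is therefore estimated at 6200 nM, between 3000 nM and 13000 nM.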

Compound 4, half-maximal effective concentration: 1900 nM
Compound 4: the middle estimate sits 3.3-fold (0.51 log units) above what was measured; the whole stated range lies above it.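

On the core of compound 3, cyclooctyl in place of cycloheptyl on an amide-type nitrogen gives a 3.6-fold lower number from compound 3 to compound 4 (0.55 log units; beyond the scatter) in this assay, so the step seen on the core of compound 1 does not carry over in size: the same change on two cores in this assay, a 1.1-fold lower number (0.03 log units; within the scatter) from compound 1 to compound 2 and a 3.6-fold lower number (0.55 log units; beyond the scatter) from compound 3 to compound 4, 3.3-fold (0.52 log units) apart, beyond the scatter of two such steps. With cyclooctyl on the amide, pyrrolidin-1-yl in place of 4-methylpiperazin-1-yl gives a 1.3-fold lower number from compound 2 to compound 4 (0.12 log units; within the scatter), which does not match the same change with cycloheptyl: the same change on two cores in this assay, a 2.5-fold higher number (0.40 log units; beyond the scatter) from compound 1 to compound 3 and a 1.3-fold lower number (0.12 log units; within the scatter) from compound 2 to compound 4, 3.3-fold (0.52 log units) apart, beyond the scatter of two such steps. The two changes therefore do not add up across these compounds, but a single set of four shows neither a general rule nor a reason for it.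

As far as these compounds go, it remains open whether the cyclooctyl step recurs with other amines on the chain, such as piperidin-1-yl or morpholin-4-yl. The same applies to a shorter or longer chain.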